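Exchanging the Pyridinyl Group on a Shared Core

The source may report more compounds than this note shows. Statements on the series, on what has been measured and on what is new or still open speak of the compounds shown alone.

Compound 1 `O=C(c1cncc(Br)c1)N1N=C(c2ccc(Cl)cc2)CC1c1ccc(OCc2ccccc2)cc1` was tested in a functional assay on WM 266-4 cells (Homo sapiens) for antiproliferative activity, read by MTT assay, with a stated time of 24 h (on this read-out higher numbers stand for weaker inhibition of growth and lower numbers for stronger inhibition of growth), where compound 1 gives 8130 nM. Compound 2 `O=C(c1ccc(Cl)nc1)N1N=C(c2ccc(Cl)cc2)CC1c1ccc(OCc2ccccc2)cc1` differs from it in one place, (6-chloropyridin-3-yl in place of 5-bromopyridin-3-yl on a carbonyl carbon). In this assay compound 2 gives 13200 nM, a step of a 1.6-fold higher number from compound 1 to compound 2 (0.21 log units; within the scatter). Compound 3 `O=C(c1cncc(Br)c1)N1N=C(c2ccc(Cl)cc2)CC1c1ccc(Br)cc1` keeps the carbonyl group of compound 1 but sits on a different core; the difference between the two cores is bromo in place of benzyloxy on an aromatic carbon. In this assay compound 3 gives 8010 nM, so that a 1.0-fold lower number from compound 1 to compound 3 (0.01 log units; within the scatter).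

Compound 4 `O=C(c1ccc(Cl)nc1)N1N=C(c2ccc(Cl)cc2)CC1c1ccc(Br)cc1` is not yet measured. It stands to compound 3 as compound 2 stands to compound 1: 6-chloropyridin-3-yl in place of 5-bromopyridin-3-yl on a carbonyl carbon, the same change at the same place, made twice among these four compounds. Within the data shown here, the single measured instance, a 1.6-fold higher number from compound 1 to compound 2 (0.21 log units; within the scatter), stayed within the scatter, and that is all the expectation for compound 4 rests on. Compound 4 is therefore expected to give about 12500 nM in this assay, with a likely range from 6000 nM to 26000 nM. That estimate means a 1.6-fold higher number from compound 3 to compound 4 (0.19 log units; within the scatter), a step mirroring the one seen before.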

Compound 4, concentration for 50% growth inhibition: 9870 nM
Estimate against measurement, compound 4: 1.3-fold (0.10 log units) above; the range from low to high includes it.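

On the core of compound 3, 6-chloropyridin-3-yl in place of 5-bromopyridin-3-yl gives in this assay a 1.2-fold higher number from compound 3 to compound 4 (0.09 log units; within the scatter), and this step agrees with the one seen on the core of compound 1: the same change on two cores in this assay, a 1.6-fold higher number (0.21 log units; within the scatter) from compound 1 to compound 2 and a 1.2-fold higher number (0.09 log units; within the scatter) from compound 3 to compound 4, 1.3-fold (0.12 log units) apart, within the scatter of two such steps

The second change in this set, bromo in place of benzyloxy, gives a 1.3-fold lower number from compound 2 to compound 4 (0.13 log units; within the scatter) and also holds when the carbonyl group is exchanged: the same change on two cores in this assay, a 1.0-fold lower number (0.01 log units; within the scatter) from compound 1 to compound 3 and a 1.3-fold lower number (0.13 log units; within the scatter) from compound 2 to compound 4, 1.3-fold (0.12 log units) apart, within the scatter of two such steps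

So the exchange carries over between these two cores in the limited sense that it stays within the scatter on both, but since neither step stands out from the scatter, this does not show that the change has any real effect to carry, nor does it show anything about other cores or other assays.

The compounds shown leave open whether an amine or a methoxy group on the pyridine ring would move the number beyond the scatter. They also leave open what a carboxylic acid or a longer chain would do in place of bromo or benzyloxy on the aromatic carbon.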